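A few compounds are considered here, and "the series" means these few. Any claim that something is new, unique, unknown or untested is made for them only; others in the source may bear on it.

Measured so far:
compound 1, `O=C(CCCCCc1cccc(O)c1)N1CCOC1=O` — 8640 nM
compound 2, `O=C(O)c1cccc(CCCCCC(=O)N2CCOC2=O)c1` — > 20000 nM

In an assay on HEK293 cells for inhibition of N-acylethanolamine-hydrolyzing acid amidase (Rattus norvegicus), read by LC-MS, with a stated time of 30 min (on this read-out higher numbers stand for weaker inhibition and lower numbers for stronger inhibition), compound 1 gives 8640 nM. For compound 2 this assay reports only a limit, > 20000 nM, and no number. Within the data shown here, the single measured step, an at least 2.3-fold higher number from compound 1 to compound 2 (0.36 log units; beyond the scatter), is therefore known only as a lower bound; compound 2 sits at the limit of > 20000 nM in this assay, at which 1 of the 2 values shown sits.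

Compound 3, `Nc1cccc(CCCCCC(=O)N2CCOC2=O)c1`, is not yet measured. It differs from compound 2 by amino in place of carboxy on an aromatic carbon. Among the measured compounds shown here, this is the reverse direction of the one step on record: the carboxy that took compound 2 to the limit leaves, and a small neutral substituent, amino, takes its place, as hydroxy did in compound 1. Compound 3 is therefore expected to come back within a number, somewhere around the level of compound 1, though a further limit cannot be excluded. The estimate for compound 3 is 12000 nM, range 4000 nM to 40000 nM, which would mean an expected step of an at least 1.6-fold lower number from compound 2 to compound 3 (0.22 log units; that floor lies within the scatter) measured against a limit.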

Compound 3, half-maximal inhibitory concentration: > 20000 nM
Compound 3 ended at the assay's limit; the forecaster's own chance of this, stated with the estimate: 30%; middle value at least 1.6-fold (0.22 log units) from the limit.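

Amino in place of hydroxy on the aromatic carbon gives an at least 2.3-fold higher number from compound 1 to compound 3 (0.36 log units; beyond the scatter). The loss seen from compound 1 is therefore no longer tied to carboxy alone, and of the three groups shown at this place, only hydroxy returns a number in this assay. Both compound 2 and compound 3 are limits, so the step between them cannot be read, and the series now stands as follows: the limit of > 20000 nM in this assay, at which 2 of the 3 values shown sit.

From the compounds shown here alone, what compound 2 and compound 3 would give as numbers stays unknown, so carboxy and amino cannot be put in order. Going by these compounds, whether a methoxy group or a fluorine atom at this place, or a shorter or longer chain with hydroxy kept, would give a number at or below that of compound 1 remains open.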